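The source may hold more compounds than are shown below. What is called first, only, known or untested is meant among the compounds shown, and "the series" means these compounds.

Measured in a functional assay on MGC-803 cells (Homo sapiens) for antiproliferative activity, read by CellTiter-Glo, with a stated time of 72 h; on this read-out higher numbers stand for weaker inhibition and lower numbers for stronger inhibition:
- compound 1 `O=C(NO)c1cccc(/C=C/c2ccnc(-c3ccccc3O)c2)c1`: 2810 nM
- compound 2 `O=C(NO)c1ccc(/C=C/c2ccnc(-c3cccc(O)c3)c2)cc1`: 2100 nM

Going by the values given here, the values of these two compounds lie within the scatter of each other, so compound 2 sits level with compound 1 on the numbers so far. Compound 3 `Cc1ccc(-c2cc(/C=C/c3ccc(C(=O)NO)cc3)ccn2)cc1` is unmeasured and follows from compound 2 by one change: 4-methylphenyl in place of 3-hydroxyphenyl on an aromatic carbon, with 4-methylphenyl in place of 3-hydroxyphenyl next to the ring nitrogen. Among the compounds with values here, no measured step covers this change, so no step beyond the scatter is expected in this assay, and no direction is favoured. The expected outcome is a 1.1-fold lower number from compound 2 to compound 3 (0.02 log units; within the scatter). For compound 3 the estimated value is 2000 nM, with an expected range of 700 nM to 6000 nM.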

Compound 3, half-maximal inhibitory concentration: 1910 nM
For compound 3 the middle estimate is 1.0-fold (0.02 log units) above the measured one; the measured number falls inside the stated range.
By their numbers in this assay, from the lowest: compounds 3, 2 and 1 (each within the scatter of the next).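

In this assay, going by these compounds alone, 4-methylphenyl in place of 3-hydroxyphenyl on the aromatic carbon next to the ring nitrogen gives a 1.1-fold lower number from compound 2 to compound 3 (0.04 log units; within the scatter) and is the first one-place comparison. The hydrogen-bond donor and acceptor counted on 3-hydroxyphenyl are absent from 4-methylphenyl, yet the two values remain level, so in this pair neither is needed to hold the number at this position. As far as these compounds go, whether an amine or a carboxylic acid on this carbon would also stay level remains open. No measurement on hand explains the level values.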